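The source may report more compounds than this note shows. Statements on the series, on what has been measured and on what is new or still open speak of the compounds shown alone.

Measured compounds:
- compound 1 `C/C1=C\CC[C@@](C)(O)/C=C/[C@]2(C(C)C)CC/C(=C\CC1)C(=O)O2` — in a functional assay on HeLa cells (Homo sapiens) for antiproliferative activity, read by MTT assay (on this read-out higher numbers stand for weaker inhibition and lower numbers for stronger inhibition), compound 1 gives "not active" (no number reported)
- compound 2 `C/C1=C\CC[C@](C)(O)/C=C/[C@]2(C(C)C)CC/C(=C/CC1)C(=O)O2` — in this assay compound 2 gives 38400 nM
- compound 3 `C/C1=C\C=C(\C(C)C)CC/C(C(=O)O)=C\CC/C(C)=C/CC1` — in this assay compound 3 gives "not active" (no number reported)

Among these three, compound 2 is the only one with a number to its name in this assay; compound 1 and compound 3 were recorded without one, as not active. Even so, the number for compound 2 lies in the weakly inhibiting region of this assay. It is worth noting (the fact that compounds 1 and 2 differ only in the configuration as drawn), so that a change of configuration alone separates a weak number from no activity at all.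

The step now followed leads from compound 2 to compound 4 `C/C1=C\CC[C@](C)(O)/C=C/[C@]2(C(C)C)CC/C(=C\CC1)C(=O)O2`. The difference is small on paper: the two compounds have the same atoms and bonds and differ only in configuration as drawn: 1 of 5 stereo elements differ; a double bond is drawn Z in compound 2 and E in compound 4.

For the measured compounds named here, since no measured pair in this set isolates the geometry of that double bond, there is no direct guide to its effect. Going by the values given here, the one configurational comparison available, compound 1 against compound 2, shows that such changes can push a compound from a weak number to none. The expectation for compound 4 in this assay is therefore a step of a 1.6-fold higher number from compound 2 to compound 4 (0.19 log units; within the scatter) toward weaker inhibition, possibly beyond the scatter, with a real chance that only inactivity is reported. The estimate for compound 4 is 60000 nM, within 15000 nM to 200000 nM.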

Compound 4, half-maximal inhibitory concentration: "not active" (no number reported)
Nothing numeric was reported for compound 4; no gap can be computed for the estimate.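

In this assay, for the compounds shown here, compound 4 gives "not active" (no number reported), whereas compound 2 gives 38400 nM, so no step between these two compounds can be read. The compounds shown leave open how large an effect the double-bond geometry has, and whether compound 1, compound 3 and compound 4 have any measurable activity in this assay.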